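The compounds below may be only part of what the source reports. "The series", "measured", "known", "first", "only" and "open" are said of these compounds alone.

Compound 1 `Nc1ccc2cccc(OCCC(F)(F)F)c2n1` carries a trifluoromethyl group on the chain and gives 722 nM in an assay on cells with melanin-concentrating hormone receptor 1 (Homo sapiens) as the target, read by radioligand binding; a lower number here means a stronger inhibitor, a higher number a weaker inhibitor. Compound 2 `CC(C)(C)CCOc1cccc2ccc(N)nc12` carries tert-butyl in the same place and gives 201 nM; the step of a 3.6-fold lower number from compound 1 to compound 2 (0.56 log units; beyond the scatter) favours the tert-butyl chain. Compound 3 `CSCCOc1cccc2ccc(N)nc12`, with methylsulfanyl, reaches only the limit of the assay and gives > 2000 nM. Compound 3 therefore stands at the weak end of the three measured compounds, as shown by an at least 2.7-fold higher number from compound 1 to compound 3 (0.44 log units; beyond the scatter) and an at least 9.9-fold higher number from compound 2 to compound 3 (0.99 log units; beyond the scatter), both resting on (the limit of > 2000 nM in this assay, at which 1 of the 3 values shown sits).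

Compound 4 `Nc1ccc2cccc(OCC3CC3)c2n1` has not yet been measured. cyclopropyl in place of (methylsulfanyl)methyl on a saturated chain carbon bound to an oxygen on an aromatic ring The two steps that bear on this change each run from a carbon-only group to the sulfur-bearing one and each worsen the number, the larger being an at least 9.9-fold higher number from compound 2 to compound 3 (0.99 log units; beyond the scatter). Running the same change the other way, toward a carbon-only group again, the number for compound 4 is expected to fall, with an at least 4.4-fold lower number from compound 3 to compound 4 (0.64 log units; beyond the scatter) as the expected step. In this assay compound 4 is thus estimated at 450 nM, within a range from 150 nM to 1500 nM.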

Compound 4, half-maximal inhibitory concentration: > 2000 nM
Compound 4 ended at the assay's limit (the forecaster's own chance of this, stated with the estimate: 10%); middle value at least 4.4-fold (0.64 log units) from the limit.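

In this assay compound 4 gives > 2000 nM, which is a limit of the assay and not a number, so a carbon-only group on this chain does not by itself move a compound away from the limit. Putting cyclopropyl in place of neopentyl brings an at least 9.9-fold higher number from compound 2 to compound 4 (0.99 log units; beyond the scatter), and putting it in place of 2,2,2-trifluoroethyl brings an at least 2.7-fold higher number from compound 1 to compound 4 (0.44 log units; beyond the scatter). The step between compound 3 and compound 4 cannot be read, and a sulfur-bearing chain and a carbon-only chain now stand together at the weak end: the limit of > 2000 nM in this assay, at which 2 of the 4 values shown sit.

On these data alone, how compound 3 and compound 4 truly stand relative to each other remains open. Also open, as far as these compounds go, is how a longer chain ending in tert-butyl, or an amine at the end of the chain, would read in this assay.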